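Working notes: chain extension, compound 2 to compound 4

The compounds below may be only part of what the source reports. "The series", "measured", "known", "first", "only" and "open" are said of these compounds alone.

Values in a functional assay on SW480 cells (Homo sapiens) for antiproliferative activity, read by MTT assay, with a stated time of 48 h; on this read-out lower numbers stand for stronger inhibition and higher numbers for weaker inhibition:
- compound 1 `CCC(CCO)n1cnc2c(Cl)nc(F)nc21`: 19800 nM
- compound 2 `CCCC(CCO)n1cnc2c(Cl)nc(F)nc21`: 17200 nM
- compound 3 `CCCC(CCO)n1cnc2c(Cl)ncnc21`: > 50000 nM, a limit of the assay and not a number

Compound 2 at 17200 nM stands within the scatter of compound 1 at 19800 nM. Compound 4 `CCCCCC(CCO)n1cnc2c(Cl)nc(F)nc21` differs from compound 2 by ethyl in place of hydrogen on a saturated chain carbon, four bonds along the chain from an aromatic nitrogen, or propyl to pentyl. For the measured compounds named here, the one measured chain step is a 1.2-fold lower number from compound 1 to compound 2 (0.06 log units; within the scatter). The fluoro step, an at least 2.9-fold higher number from compound 2 to compound 3 (0.46 log units; beyond the scatter), is not repeated here and does not bear on this change. No step beyond the scatter is therefore expected in this assay, and the expected step is a 1.1-fold lower number from compound 2 to compound 4 (0.06 log units; within the scatter). Compound 4 is estimated at 15000 nM, with an expected range of 7000 nM to 32000 nM.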

Compound 4, half-maximal inhibitory concentration: 7440 nM
Compound 4: the middle estimate sits 2.0-fold (0.30 log units) above what was measured; the range from low to high includes it.
By their numbers in this assay, from the lowest: compound 4; then compounds 2 and 1 (each within the scatter of the next). At a limit, above all of these: compound 3.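

In this assay, for the compounds shown here, the chain position, flat on the one earlier step, now responds: the change to pentyl gives a 2.3-fold lower number from compound 2 to compound 4 (0.36 log units; beyond the scatter) and separates compound 4 from compound 2. Measured from the shortest chain here, the series gives a 2.7-fold lower number from compound 1 to compound 4 (0.43 log units; beyond the scatter) as its largest chain step. The earlier 1.2-fold lower number from compound 1 to compound 2 (0.06 log units; within the scatter) gave no sign of this.

As far as these compounds go, whether a chain longer than pentyl, or an amine or carboxylic acid at the chain end, would continue this trend stays open. Nothing shown accounts for the change with chain length.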